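The compounds below may be only part of what the source reports. "The series", "measured", "known", "first", "only" and "open" are said of these compounds alone.

Measured so far:
- compound 1 `Cc1cc(OC[C@@H]2CN(C)c3ccccc3O2)ccc1C(=O)Nc1cccc(CC(=O)O)c1C`: 59 nM
- compound 2 `Cc1cc(OC[C@@H]2CN(C)c3ccccc3O2)ccc1C(=O)Nc1cc(CC(=O)O)ccc1Cl`: 7.7 nM

In an assay on CHO cells for displacement of a labelled ligand from prostaglandin D2 receptor (Mus musculus), read by scintillation counting, with a stated time of 60 min (on this read-out lower numbers stand for stronger inhibition and higher numbers for weaker inhibition), compound 2 gives the lowest of the two numbers; its nearest neighbour is compound 1, and the step of a 7.7-fold lower number from compound 1 to compound 2 (0.88 log units; beyond the scatter) lies beyond the scatter. Compound 3 `Cc1cc(OC[C@@H]2CN(C)c3ccccc3O2)ccc1C(=O)Nc1cc(F)cc(CC(=O)O)c1` differs from compound 2 by 3-(carboxymethyl)-5-fluorophenyl in place of 5-(carboxymethyl)-2-chlorophenyl on an amide-type nitrogen. Among the measured compounds shown here, only the step from compound 1 to compound 2 bears on this change, and it altered both the carboxymethyl position and the second ring substituent at once, so it is an uncertain guide. A modest rise in the number from compound 2 to compound 3 is expected, a 2.6-fold higher number from compound 2 to compound 3 (0.41 log units; beyond the scatter). For compound 3 the estimate in this assay is 20 nM, within 6 nM to 70 nM.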

Compound 3, inhibition constant: 7.4 nM
The estimate for compound 3 lay 2.7-fold (0.43 log units) above the measured number; the measured number falls inside the stated range.
By their numbers in this assay, from the lowest: compounds 3 and 2 (each within the scatter of the next); then compound 1.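

Two different rings on the amide-type nitrogen now give indistinguishable numbers in this assay: replacing 5-(carboxymethyl)-2-chlorophenyl with 3-(carboxymethyl)-5-fluorophenyl gives a 1.0-fold lower number from compound 2 to compound 3 (0.02 log units; within the scatter), so the low number does not depend on the chlorine-bearing ring. Both rings are named with carboxymethyl at 3 or 5, yet the 3-(carboxymethyl)-2-methylphenyl ring stands apart, with an 8.0-fold lower number from compound 1 to compound 3 (0.90 log units; beyond the scatter) as the step to the fluorinated ring. Nothing available explains either step.

Left open is whether a longer chain carrying the carboxylic acid would keep the number. Also open, from the compounds shown here alone, is whether an amine on the ring in place of fluorine would do so.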